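The compounds below may be only part of what the source reports. "The series", "measured", "known", "first", "only" and "open" are said of these compounds alone.

Measured in a functional assay on HCT-116 cells (Homo sapiens) for inhibition, read by CCK-8 assay, with a stated time of 72 h, tested at 8 uM (on this read-out higher numbers stand for more inhibition of growth at the one concentration tested and lower numbers for less inhibition of growth), so far:
- compound 1 `Cc1cc(C)cc(SCc2ccc(/C=C/C(=O)Nc3ccccc3N)cc2)c1` gives 4.2%
- compound 2 `CCc1ccc(SCc2ccc(/C=C/C(=O)Nc3ccccc3N)cc2)cc1` gives 2.68%
- compound 3 `COc1ccc(SCc2ccc(C(=O)Nc3ccccc3N)cc2)cc1` gives 90.1%

Compound 2 sits within the scatter of compound 1 at the low end of these numbers, far from compound 3 with its 90.1% reading.

Compound 4 `Nc1ccccc1NC(=O)/C=C/c1ccc(CSCCc2ccccc2)cc1` carries phenethyl in place of 4-ethylphenyl on a sulfur and is still unmeasured. Going by the values given here, the only measured step at this sulfur is small: a number 1.5 percentage points lower from compound 1 to compound 2 (within the scatter). Among the compounds with values here, no measured compound carries phenethyl, so this step is weak guidance. The expected change is therefore none beyond the scatter, with an estimated step of a number 5.3 percentage points higher from compound 2 to compound 4 (within the scatter) in this assay. The estimate for compound 4 is 8%, with an expected range from 0% to 30%.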

Compound 4, percent growth inhibition at one concentration: 10.6%
Compound 4: the middle estimate sits 2.6 percentage points below what was measured; measured number inside the range.
By their numbers in this assay, from the lowest: compounds 2, 1 and 4 (each within the scatter of the next); then compound 3.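

In this assay the steps of a number 7.9 percentage points higher from compound 2 to compound 4 (within the scatter) and a number 6.4 percentage points higher from compound 1 to compound 4 (within the scatter) both lie within the scatter. The read-out at this sulfur therefore stays low not only with the substituted phenyl groups but also with phenethyl, which has the same heavy-atom count as 4-ethylphenyl but joins its ring differently. No measurement on hand explains this insensitivity.

From the compounds shown here alone, whether a benzyl group, a longer chain or a terminal amine on this sulfur would lift the number remains open. So does the reading of phenethyl on the core of compound 3 .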